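Swapping a Valine Side Chain for a Methionine One

The source may report more compounds than this note shows. Statements on the series, on what has been measured and on what is new or still open speak of the compounds shown alone.

Compound 1 `O=C(NS(=O)(=O)c1ccc(NCCSc2ccccc2)c([N+](=O)[O-])c1)c1ccc(NC(=O)c2ccccc2F)cc1` and compound 2 `CC(=O)N[C@H](C(=O)Nc1ccc(C(=O)NS(=O)(=O)c2ccc(NCCSc3ccccc3)c([N+](=O)[O-])c2)cc1)C(C)C` share one core; in an assay on isolated protein for binding affinity to Apoptosis regulator Bcl-2 (Homo sapiens), read by fluorescence polarization (on this read-out lower numbers stand for stronger inhibition and higher numbers for weaker inhibition), compound 1 gives 1090 nM, and compound 2 gives 9490 nM. Within the data shown here, compound 2 therefore stands at the higher of the two numbers, and the only step recorded so far, an 8.7-fold higher number from compound 1 to compound 2 (0.94 log units; beyond the scatter), comes from putting a 1-acetamido-2-methylpropyl group in place of a 2-fluorophenyl group on a carbonyl carbon.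

Compound 3 `CSCC[C@H](NC(C)=O)C(=O)Nc1ccc(C(=O)NS(=O)(=O)c2ccc(NCCSc3ccccc3)c([N+](=O)[O-])c2)cc1` keeps everything in compound 2 except one group: 2-(methylsulfanyl)ethyl in place of isopropyl on a saturated chain carbon bound to an amide-type nitrogen and a carbonyl carbon. Among the measured compounds shown here, no measured step touches this position, so the single known step, which changed a different part of the molecule, bears on it only by showing that changes in this region of compound 2 can move the number noticeably. With nothing that speaks to a switch of one small chain for another, the expectation is a step not beyond the scatter, a little toward a lower number if anything, a 1.4-fold lower number from compound 2 to compound 3 (0.13 log units; within the scatter). Compound 3 is thus estimated at 7000 nM in this assay, with a plausible range from 2500 nM to 20000 nM.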

Compound 3, inhibition constant: 3520 nM
For compound 3 the middle estimate is 2.0-fold (0.30 log units) above the measured one; the measured number falls inside the stated range.
By their numbers in this assay, from the lowest: compound 1; then compound 3; then compound 2.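

In this assay, the saturated chain carbon bound to an amide-type nitrogen and a carbonyl carbon proves to be a position that matters: a 2.7-fold lower number from compound 2 to compound 3 (0.43 log units; beyond the scatter) comes from 2-(methylsulfanyl)ethyl in place of isopropyl, so exchanging one small chain for another moves the number beyond the usual scatter. That change does not bring the series back to its earlier level, since a 3.2-fold higher number from compound 1 to compound 3 (0.51 log units; beyond the scatter) remains with 1-acetamido-3-(methylsulfanyl)propyl in place of 2-fluorophenyl on a carbonyl carbon; the new chain therefore recovers only part of the ground lost on leaving the 2-fluorophenyl group. Nothing available explains why the chain with sulfur gives the lower number.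

The compounds shown leave open whether the sulfur atom itself counts or only the longer reach of the chain, a question that a plain butyl chain at this place could help to settle. Also open, as far as these compounds go, is whether an amine or a carboxylic acid at the end of this chain would take the number lower, or higher, than the methylsulfanyl group does.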